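Triazole for cyclopropylsulfamoyl: kinetic solubility at low pH

A few compounds are considered here, and "the series" means these few. Any claim that something is new, unique, unknown or untested is made for them only; others in the source may bear on it.

Compound 1 `COc1ccc(-c2cc(-c3ccc(S(=O)(=O)NC4CC4)cc3)cnc2N)cn1` stands at the ceiling of a physicochemical assay for solubility, read by nephelometry, measured as kinetic solubility, at pH 2; a lower number here means a less soluble compound, a higher number a more soluble compound: compound 1 gives > 100 ug/mL, a limit rather than a number. Compound 2 `COc1ccc(-c2cc(-c3ccc(S(C)(=O)=O)c(F)c3)cnc2N)cn1` likewise gives > 100 ug/mL, also a limit. Compound 3 `COc1ccc(-c2cnc(N)c(-c3ccc(OC)nc3)c2)cn1` gives > 100 ug/mL, again a limit. Among the measured compounds shown here, all three sit at the limit of > 100 ug/mL in this assay, at which 3 of the 3 values shown sit, so no step between measured compounds can be sized. Compound 4 `COc1ccc(-c2cc(-c3ccc(-n4cncn4)cc3)cnc2N)cn1` differs from compound 1 by 1H-1,2,4-triazol-1-yl in place of cyclopropylsulfamoyl on an aromatic carbon. With every shown value at the limit, no direction of change in this assay can be read from the series. The step from compound 1 to compound 4 is expected at a step that the limit leaves unreadable from compound 1 to compound 4, none beyond the scatter. Compound 4 is expected to give 150 ug/mL in this assay, between 60 ug/mL and 400 ug/mL, most likely reported again as a limit.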

Compound 4, solubility: > 100 ug/mL
Compound 4 was reported as a limit (the forecaster's own chance of this, stated with the estimate: 70%); the middle value does not contradict the limit.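

In this assay compound 4 gives > 100 ug/mL, a limit, so no step from compound 1 to compound 4 can be read: the limit of > 100 ug/mL in this assay, at which 4 of the 4 values shown sit.

The compounds shown leave open whether 1H-1,2,4-triazol-1-yl in place of cyclopropylsulfamoyl changes the solubility at all.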